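Hydroxymethyl to methoxymethyl on compound 1

A few compounds are considered here, and "the series" means these few. Any claim that something is new, unique, unknown or untested is made for them only; others in the source may bear on it.

In a functional assay on K562 cells (Homo sapiens) for cytotoxicity, with a stated time of 72 h (a lower number here means a stronger inhibitor, a higher number a weaker inhibitor), compound 1 (`Cc1cccc(-c2nn3c(c2-c2ccncc2)C(CO)C(C)(C)C3)n1`) gives > 100000 nM as a limit of the assay and not a number. Compound 2 (`Cc1cc(-c2c(-c3cccc(C)n3)nn3c2C(C)C(C)(C)C3)ccn1`) gives > 100000 nM as a limit too. Compound 3 (`CCc1cccc(-c2nn3c(c2-c2ccncc2)C(C)C(C)(C)C3)n1`) likewise gives > 100000 nM as a limit. Compound 1 therefore stands at a limit (the limit of > 100000 nM in this assay, at which 3 of the 3 values shown sit) and has no number to step from.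

Compound 4 (`COCC1c2c(-c3ccncc3)c(-c3cccc(C)n3)nn2CC1(C)C`) is the next to be read, with methyl in place of hydrogen on an oxygen on a saturated carbon as the change: methyl in place of hydrogen on an oxygen on a saturated carbon, which turns hydroxymethyl into methoxymethyl. Among the compounds with values here, no step between measured compounds is available, so the size of this change has no direct precedent. In this assay no step beyond the scatter is expected. This expectation rests on compound 1 with its limit of > 100000 nM as the only starting point. The expected a number no higher from compound 1 to compound 4 (the limit leaves the size open) is therefore a nominal one. Compound 4 is estimated at 100000 nM with an expected range of 40000 nM to 250000 nM and will most likely be reported as a limit again.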

Compound 4, half-maximal inhibitory concentration: > 100000 nM
Compound 4: no number, only a limit; the forecaster's own chance of this, stated with the estimate: 85%; the middle value lies on the limit itself.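

In this assay, within the data shown here, compound 1 and compound 4 both stand at a limit of the assay and not at a number, so no step from hydroxymethyl to methoxymethyl can be read. The compounds shown leave open whether any change on the shared core gives a measurable half-maximal inhibitory concentration in this assay at all.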